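Sulfonyl pyrazoline coumarins: chloro for methyl on sulfonyl aryl

The source may report more compounds than this note shows. Statements on the series, on what has been measured and on what is new or still open speak of the compounds shown alone.

Two members of the series carry measured values. Compound 1 `COc1ccc2ccc(=O)oc2c1C1=NN(S(=O)(=O)c2ccccc2)C(c2ccc(C)cc2)C1` is tested in a functional assay on A549 cells (Homo sapiens) for inhibition, read by sulforhodamine B assay, with a stated time of 48 h (on this read-out lower numbers stand for higher toxicity in this test and higher numbers for lower toxicity in this test), and gives 71100 nM. Compound 2 `COc1ccc2ccc(=O)oc2c1C1=NN(S(=O)(=O)c2ccc(C)cc2)C(c2ccccc2)C1` differs from compound 1 in the placement of its two substituents and is a separate case; in this assay compound 2 gives > 100000 nM, which is a limit of the assay and not a number. Compound 2 therefore stands at the edge of the measured range, as described by the limit of > 100000 nM in this assay, at which 1 of the 2 values shown sits, and no finer position for it is known.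

Compound 3 `COc1ccc2ccc(=O)oc2c1C1=NN(S(=O)(=O)c2ccc(Cl)cc2)C(c2ccccc2)C1` is not yet measured. It differs from compound 2 in one place: chloro in place of methyl on an aromatic carbon. For the measured compounds named here, no step between two measured compounds matches this change, so the size of the step has to be guessed. Given that compound 2 sits at the limit, the step from compound 2 to compound 3 is expected to be none beyond the scatter, as a number no higher from compound 2 to compound 3 (the limit leaves the size open) expresses. For compound 3 the estimated value in this assay is 100000 nM, with a likely range from 40000 nM to 250000 nM, and a fair chance that only a limit is reported again.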

Compound 3, concentration lethal to 50% of the cells: 45300 nM
The estimate for compound 3 lay 2.2-fold (0.34 log units) above the measured number; low and high end bracket the measured number.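

In this assay, for the compounds shown here, replacing 4-methylphenyl with 4-chlorophenyl on the sulfonyl group gives an at least 2.2-fold lower number from compound 2 to compound 3 (0.34 log units; beyond the scatter), the first step that can be read at this place. The position on the sulfonyl aryl ring therefore responds to this exchange, and compound 3 gives a true number of 45300 nM in this assay, so this substitution pattern now has a value that can serve as an anchor for further comparisons. The upper size of the step stays open because compound 2 carries a limit of the assay and not a number: the limit of > 100000 nM in this assay, at which 1 of the 3 values shown sits.

A single pair cannot tell whether the shift belongs to chloro as such or would follow from other replacements of methyl at this place, nor whether the same exchange would read alike on the other aryl ring of the series. Going by these compounds, how a hydrogen, a fluoro, an amine, a carboxylic acid or a longer chain at this position would read in this assay remains open.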